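This account rests on a few compounds, and the source may have more. Where it says the series, first, only, none or still open, it means among the compounds named here.

Compound 1, `O=C([C@@H]1CCCN(S(=O)(=O)c2ccc(S(=O)(=O)C3CCC3)cc2)C1)N1CCC(F)(F)CC1`, is the stronger of the two compounds measured in a functional assay on BXPC-3 cells (Homo sapiens) for inhibition, read by MTT assay, with a stated time of 7 days; a higher number here means a weaker inhibitor, a lower number a stronger inhibitor. In that assay compound 1 gives 78 nM. Within the data shown here, the other measured compound, compound 2, `CCN(CC)S(=O)(=O)c1ccc(S(=O)(=O)N2CCC[C@@H](C(=O)N3CCC(COC)CC3)C2)cc1`, gives 1360 nM in this assay; it differs from compound 1 in more than one place, so the pair shows only that compound 2 lies well above compound 1, beyond the scatter, and no single change can be read from it.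

Compound 3, `O=C([C@@H]1CCCN(S(=O)(=O)c2ccc(S(=O)(=O)N3CC[C@H](O)C3)cc2)C1)N1CCC(F)(F)CC1`, has not yet been measured. It differs from compound 1 in a single place: 3-hydroxypyrrolidin-1-yl in place of cyclobutyl on a sulfonyl sulfur. The rest of the shared core is unchanged. Among the measured compounds shown here, no pair of measured compounds differing in only one place is available, so there is nothing to anchor the size of this step. The step from compound 1 to compound 3 in this assay is expected to be modest, a 1.9-fold higher number from compound 1 to compound 3 (0.28 log units; within the scatter), with a weakening somewhat more likely than a gain. For compound 3 the estimated value in this assay is 150 nM, with a range from 50 nM to 600 nM.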

Compound 3, half-maximal inhibitory concentration: 580 nM
For compound 3 the middle estimate is 3.9-fold (0.59 log units) below the measured one, and the stated range covers the measured number.
By their numbers in this assay, from the lowest: compound 1; then compound 3; then compound 2.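

Among these compounds, this is the first comparison in the set that isolates the group on the sulfonyl sulfur, and in this assay that group proves not to be interchangeable, with a 7.4-fold higher number from compound 1 to compound 3 (0.87 log units; beyond the scatter) when 3-hydroxypyrrolidin-1-yl takes the place of cyclobutyl. Among the compounds shown here, the single step nevertheless bundles several differences, since a carbon-only four-membered ring with no hydrogen-bond donor or acceptor gives way to a larger five-membered ring that has one hetero atom, one donor, one acceptor and a defined stereocentre. Nothing measured here explains the loss or assigns it to any one of these differences.

As far as these compounds go, what remains open is whether the step follows the hydroxyl group, the ring nitrogen on the sulfonyl sulfur, the ring size or the stereocentre, which unsubstituted pyrrolidin-1-yl, cyclopentyl or the opposite 3-hydroxypyrrolidin-1-yl stereoisomer at this place could help to separate. From the compounds shown here alone, it is also open whether cyclobutyl is unusually favourable here or simply better than this one replacement, a question that cyclopropyl or a longer alkyl chain on the same sulfur would bear on.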